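From anilino to dimethylamino on a carbonyl carbon

This account rests on a few compounds, and the source may have more. Where it says the series, first, only, none or still open, it means among the compounds named here.

Compound 1 `CN(C)C(=O)c1cccc2ccccc12`: > 50 ug/mL
Compound 2 `COC(=O)c1ccc2c(C(=O)Nc3ccccc3)cn(C)c2c1`: < 1 ug/mL
Compound 3 `COC(=O)c1ccc2c(ccn2C(=O)c2ccccc2)c1`: < 1 ug/mL

All three values come from a physicochemical assay for solubility, with a stated time of 24 h, at pH 4.5; a higher number here means a more soluble compound, a lower number a less soluble compound. Compound 2 stands at < 1 ug/mL, which is a limit of the assay and not a number. Compound 3 gives < 1 ug/mL, which is likewise a limit.

Compound 4 `COC(=O)c1ccc2c(C(=O)N(C)C)cn(C)c2c1` keeps the rest of compound 2 and changes one place: dimethylamino in place of anilino on a carbonyl carbon.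

Among the compounds with values here, no two measured compounds differ in just one place, so no direct step is available as a guide for this assay. The closest clue is compound 1, which also carries dimethylamino on a carbonyl carbon but has a different core. Compound 1 gives > 50 ug/mL, a limit of the assay. A caution comes from compound 3, which has no anilino and still sits at a limit.

On this slim basis, a rise well beyond the usual scatter is expected, an at least 20-fold higher number from compound 2 to compound 4 (1.30 log units; beyond the scatter), although the size of this expected step is uncertain since it starts from a limit. Compound 4 is estimated at 20 ug/mL, with an expected range of 4 ug/mL to 50 ug/mL.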

Compound 4, solubility: > 52 ug/mL
Compound 4: no number, only a limit; the forecaster's own chance of this, stated with the estimate: 30%; at least 2.6-fold (0.41 log units) between middle value and limit.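

On the shared core, replacing anilino with dimethylamino on a carbonyl carbon can be read as a single change, and in this assay it gives an at least 52-fold higher number from compound 2 to compound 4 (1.71 log units; beyond the scatter). Both ends of this step are limits of the assay and not numbers, so the printed size is only the smallest the real change can be, and the real change may be larger. Compound 4 keeps everything else in compound 2, so the shared core alone does not fix the low reading of compound 2, and compound 4 itself ends at a limit of the assay: the limit of > 52 ug/mL in this assay, at which 1 of the 4 values shown sits.

From the compounds shown here alone, the true solubility of compound 4 stays unknown, and so does the true size of the step, as neither compound has a number. Also open, going by these compounds, is which part of the change counts: the six-membered aromatic ring that leaves, the hydrogen-bond donor that leaves, or the dimethylamino that enters, a question that a methylamino or a morpholine on the same carbonyl carbon could begin to separate.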